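The source may hold more compounds than are shown below. What is called first, only, known or untested is meant among the compounds shown, and "the series" means these compounds.

Measured so far:
Compound 1 `CCn1nc(C)cc1C(=O)Nc1nc2cc(C(N)=O)cc(OC)c2n1CCCNC(=O)OCc1ccccc1` gives > 100000 nM in an assay for activation of interferon regulatory factor 3 (Homo sapiens), read by a luciferase reporter, with a stated time of 20 h (on this read-out higher numbers stand for an effect only at larger amounts of compound and lower numbers for an effect already at smaller amounts), which is a limit of the assay and not a number.
Compound 2 `CCCn1c(NC(=O)c2cccnn2)nc2cc(C(N)=O)cc(OC)c21` gives > 100000 nM in this assay, again a limit rather than a number.

Within the data shown here, compound 1 therefore stands at the edge of what this assay can report, and so does the only other measured compound (the limit of > 100000 nM in this assay, at which 2 of the 2 values shown sit). Among the measured compounds shown here, no step between measured compounds can be drawn from this. Compound 3 `CCn1nc(C)cc1C(=O)Nc1nc2cc(C(=O)OC)cc(OC)c2n1CCCNC(=O)OCc1ccccc1` differs from compound 1 by methoxy in place of amino on a carbonyl carbon, or carbamoyl to methoxycarbonyl. With both measured values sitting at the limit, the expected step that the limit leaves unreadable from compound 1 to compound 3 is none beyond the scatter. Compound 3 is expected to give about 150000 nM, with a range from 30000 nM to 1000000 nM, and will most likely again be reported as a limit.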

Compound 3, half-maximal effective concentration: 27600 nM
Beside the measured number, compound 3's estimate is 5.4-fold (0.74 log units) above it, and the stated range ends above it.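

Carbamoyl to methoxycarbonyl on this carbonyl carbon turns a limit into a measured number in this assay, with an at least 3.6-fold lower number from compound 1 to compound 3 (0.55 log units; beyond the scatter). Among these compounds, the group on this carbon therefore matters for the read-out, which the earlier compounds could not show. The true size of the step stays unknown because compound 1 stands at a limit: the limit of > 100000 nM in this assay, at which 2 of the 3 values shown sit.

From the compounds shown here alone, what ethoxy or methylamino on this carbonyl carbon would give remains open. So does whether the same change would also bring a measured number for compound 2.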